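The source may report more compounds than this note shows. Statements on the series, on what has been measured and on what is new or still open speak of the compounds shown alone.

Measured compounds:
compound 1, `COc1ccc(/C=N/NC(=S)NC(C)(C)[C@H]2CC=C(C)CC2)cc1`: in an ADME assay on Vero cells (Chlorocebus sabaeus) for inhibition, read by sulforhodamine B assay, with a stated time of 48 h (a lower number here means a stronger inhibitor of growth, a higher number a weaker inhibitor of growth), compound 1 gives 70100 nM
compound 2, `CC1=CC[C@H](C(C)(C)NC(=S)N/N=C/c2ccc(O)cc2)CC1`: in this assay compound 2 gives > 100000 nM, a limit of the assay
compound 3, `CC1=CC[C@H](C(C)(C)NC(=S)N/N=C/c2ccccc2O)CC1`: in this assay compound 3 gives 11200 nM

Compound 3 holds the lowest of the two numbers: the step of a 6.3-fold lower number from compound 1 to compound 3 (0.80 log units; beyond the scatter) lies beyond the scatter, and an at least 8.9-fold lower number from compound 2 to compound 3 (0.95 log units; beyond the scatter) is a floor set by the limit (the limit of > 100000 nM in this assay, at which 1 of the 3 values shown sits). Compound 4, `CC1=CC[C@H](C(C)(C)NC(=S)N/N=C/c2ccccc2Cl)CC1`, differs from compound 3 by chloro in place of hydroxy on an aromatic carbon. For the measured compounds named here, no measured step swaps hydroxy for chloro. Going by the values given here, the one step that changes a group without moving it, an at least 1.4-fold higher number from compound 1 to compound 2 (0.15 log units; that floor lies within the scatter), is a floor within the scatter; the two steps beyond the scatter both move the substituent to another aromatic carbon, which compound 4 does not do. A step of at most small size is therefore expected, a 1.3-fold higher number from compound 3 to compound 4 (0.13 log units; within the scatter). Compound 4 is estimated at 15000 nM, between 5000 nM and 60000 nM.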

Compound 4, concentration for total growth inhibition: > 100000 nM
Compound 4: no number, only a limit; the forecaster's own chance of this, stated with the estimate: 10%; at least 6.6-fold (0.82 log units) between middle value and limit.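

On this aromatic carbon, chloro in place of hydroxy in this assay gives a step beyond the scatter, an at least 8.9-fold higher number from compound 3 to compound 4 (0.95 log units; beyond the scatter), so the lowest number in the set does not carry over from 2-hydroxyphenyl to 2-chlorophenyl. Against the 4-methoxyphenyl compound, the change reads only as a floor within the scatter, an at least 1.4-fold higher number from compound 1 to compound 4 (0.15 log units; that floor lies within the scatter). The step between compound 2 and compound 4 cannot be read, as both values are limits: the limit of > 100000 nM in this assay, at which 2 of the 4 values shown sit.

Still open, on these data alone, is whether an amine or a carboxylic acid on this aromatic carbon would stay near compound 3 or reach a limit, as compound 4 does.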